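Trading a 3,4-Dimethoxybenzyl Ester for a Furylmethyl Ester

This account rests on a few compounds, and the source may have more. Where it says the series, first, only, none or still open, it means among the compounds named here.

Compound 2 `COC(=O)C1=C(C)NC(C)=C(C(=O)OCc2ccc(OC)c(OC)c2)C1c1cccc([N+](=O)[O-])c1` gives 112 nM in a functional assay on HEK293 cells for antagonist activity at Voltage-dependent L-type calcium channel subunit alpha-1C (Oryctolagus cuniculus), read by FLIPR (a higher number here means a weaker inhibitor, a lower number a stronger inhibitor), the highest of the two numbers available, while compound 1 `COC(=O)C1=C(C)NC(C)=C(C(=O)OCC(F)(F)F)C1c1cccc([N+](=O)[O-])c1` gives 16 nM. Within the data shown here, the only measured step, a 7.0-fold higher number from compound 1 to compound 2 (0.85 log units; beyond the scatter), accompanies the swap of trifluoromethyl for 3,4-dimethoxyphenyl. Compound 3 `COC(=O)C1=C(C)NC(C)=C(C(=O)OCc2ccco2)C1c1cccc([N+](=O)[O-])c1` carries furan-2-yl in place of 3,4-dimethoxyphenyl on a saturated chain carbon bound to an oxygen next to a carbonyl group. Among the measured compounds shown here, no measured step covers that exchange directly; the one step shows that the larger aromatic ester sits well above the trifluoromethyl ester. Compound 3 is therefore expected to land between the two, an estimated step of a 1.9-fold lower number from compound 2 to compound 3 (0.27 log units; within the scatter), giving 60 nM in this assay, within 20 nM to 180 nM.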

Compound 3, half-maximal inhibitory concentration: 20 nM
Estimate against measurement, compound 3: 3.0-fold (0.48 log units) above, within the range that was stated.
By their numbers in this assay, from the lowest: compounds 1 and 3 (each within the scatter of the next); then compound 2.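

In this assay an aromatic ring on this saturated chain carbon does not by itself carry the cost seen earlier: furan-2-yl in place of 3,4-dimethoxyphenyl gives a 5.6-fold lower number from compound 2 to compound 3 (0.75 log units; beyond the scatter) and so ties that cost to the 3,4-dimethoxybenzyl group among these compounds. Furan-2-yl in place of trifluoromethyl gives a 1.3-fold higher number from compound 1 to compound 3 (0.10 log units; within the scatter) and leaves those two esters indistinguishable here. Nothing available explains these differences. On these data alone, whether the gain follows from removing the two methoxy groups or from the furan ring stays open, and a plain benzyl ester or a thiophen-2-ylmethyl ester would separate the two.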